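From 3-methoxyphenyl to 4-bromophenyl on the sulfonyl sulfur

The source may hold more compounds than are shown below. What is called first, only, known or untested is meant among the compounds shown, and "the series" means these compounds.

Among the compounds with values here, in a functional assay on KB cells (Homo sapiens) for antiproliferative activity, read by sulforhodamine B assay, with a stated time of 48 h (on this read-out lower numbers stand for stronger inhibition of growth and higher numbers for weaker inhibition of growth), compound 2 `COc1cccc(S(=O)(=O)Nc2ccccc2CCc2ccc(C(=O)Nc3ccccc3N)cc2)c1` gives 462 nM, the only true number so far. In this assay, compound 1 `COc1ccc(S(=O)(=O)Nc2ccccc2CCc2ccc(C(=O)NO)cc2)cc1` gives > 10000 nM, which is a limit of the assay and not a number. Compound 3 `Nc1ccccc1NC(=O)c1ccc(CCc2ccccc2NS(=O)(=O)c2ccc(Br)cc2)cc1` carries 4-bromophenyl in place of 3-methoxyphenyl on a sulfonyl sulfur. Within the data shown here, no measured pair bears on this change, so no shift in either direction beyond the scatter is expected, and the estimated move is a 1.2-fold lower number from compound 2 to compound 3 (0.06 log units; within the scatter). For compound 3 the expected value is 400 nM, with an estimated range of 130 nM to 1400 nM.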

Compound 3, concentration for 50% growth inhibition: 124 nM
The estimate for compound 3 lay 3.2-fold (0.51 log units) above the measured number; measured number below the stated range.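

Within the data shown here, the sulfonyl sulfur is the first place where a single change can be read: in this assay, 4-bromophenyl in place of 3-methoxyphenyl gives a 3.7-fold lower number from compound 2 to compound 3 (0.57 log units; beyond the scatter), a modest step. The number at this position therefore responds to the aryl group it carries, at least for this one pair. Going by these compounds, whether that step belongs to the bromine or to where the group sits on the ring stays open, as does the effect of a 4-chlorophenyl, an amine, a carboxylic acid or a longer chain there. Nothing on hand points to a cause for this step.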